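Adding a Methoxy Group to the Benzyl Ring

The compounds below may be only part of what the source reports. "The series", "measured", "known", "first", "only" and "open" are said of these compounds alone.

Compound 1, `COc1cc2sn(CCCN(C)Cc3ccccc3)c(=O)c2cc1OC`, gives 44.4% in an assay on isolated protein for inhibition of Amine oxidase [flavin-containing] B (Homo sapiens), read by fluorescence, with a stated time of 30 min, tested at 10 uM; a higher number here means more inhibition at the concentration tested (going by the name of the read-out), a lower number less inhibition.
Compound 2, `CCN(CCCn1sc2cc(OC)c(OC)cc2c1=O)Cc1ccccc1`, gives 46.3% in this assay.

Compound 1 stands lowest of the two numbers measured, yet its nearest neighbour, compound 2, sits only a number 1.9 percentage points higher from compound 1 to compound 2 (within the scatter), so the two cannot be told apart. Compound 3, `COc1ccccc1CN(C)CCCn1sc2cc(OC)c(OC)cc2c1=O`, has not been measured. It differs from compound 1 by methoxy in place of hydrogen on an aromatic carbon, read more widely as benzyl to 2-methoxybenzyl. For the measured compounds named here, the only measured step, from compound 1 to compound 2, touches the saturated chain carbon bound to the amine nitrogen, not the aromatic ring, and it stayed within the scatter; no measured pair shows what a change on the aromatic ring does. The expectation for compound 3 is therefore a step of about a number 0.6 percentage points higher from compound 1 to compound 3 (within the scatter), none beyond the scatter. Compound 3 is estimated at 45%, between 25% and 65%.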

Compound 3, a percentage reported as inhibition, at one concentration (the size of the read-out at that concentration, not a potency): 48.6%
The estimate for compound 3 lay 3.6 percentage points below the measured number, and the stated range covers the measured number.
By their numbers in this assay, from the lowest: compounds 1, 2 and 3 (each within the scatter of the next).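

In this assay, for the compounds shown here, the first measured change on the aromatic ring, methoxy in place of hydrogen on a carbon ortho to a large group, comes out as a number 4.2 percentage points higher from compound 1 to compound 3 (within the scatter) and leaves the two compounds indistinguishable. This ring position therefore accepts a group of two heavy atoms, including a hydrogen-bond acceptor, with no shift in inhibition that rises above the scatter. Nothing shown here bears on why the result falls as it does.

Going by these compounds, a single methoxy group says little about this ring as a whole, so the outcome with a chlorine atom, a hydroxyl group or a longer ethoxy group at the same carbon remains open. Also open, on these data alone, is what methoxy would do at another carbon of the ring.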